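The source may hold more compounds than are shown below. What is called first, only, known or untested is meant among the compounds shown, and "the series" means these compounds.

Measured in a functional assay (aorta) for antagonist activity, with Oryctolagus cuniculus as the target; on this read-out lower numbers stand for stronger inhibition and higher numbers for weaker inhibition:

Compound 1 `CCCCc1ccc(CNC(=O)OC(C)(C)C)c(=O)n1Cc1ccc(-c2ccccc2-c2nn[nH]n2)cc1`: 10 nM
Compound 2 `CCCCc1ccc(CN)c(=O)n1Cc1ccc(-c2ccccc2-c2nn[nH]n2)cc1`: 20 nM
Compound 3 `CCCCc1ccc(CNCc2ccccc2)c(=O)n1Cc1ccc(-c2ccccc2-c2nn[nH]n2)cc1`: 1 nM

Compound 3 stands lowest of the three, and its distance to each of the others lies beyond the scatter: a 10-fold lower number from compound 1 to compound 3 (1.00 log units; beyond the scatter) and a 20-fold lower number from compound 2 to compound 3 (1.30 log units; beyond the scatter). Compound 4 `CCCCc1ccc(CNC(=O)Nc2ccccc2)c(=O)n1Cc1ccc(-c2ccccc2-c2nn[nH]n2)cc1` differs from compound 3 in one place: phenylcarbamoyl in place of benzyl on an amine nitrogen. Both measured steps concern the same amine nitrogen, so both bear on this change. Benzyl gave the lowest number there, whereas tert-butoxycarbonyl, which also carries a carbonyl, gave a higher one. Phenylcarbamoyl keeps one six-membered aromatic ring but brings a carbonyl, one hydrogen-bond donor and one acceptor, so a move part of the way back towards compound 1 is expected: a 5.0-fold higher number from compound 3 to compound 4 (0.70 log units; beyond the scatter). Compound 4 is estimated at 5 nM, between 1.5 nM and 20 nM.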

Compound 4, half-maximal inhibitory concentration: 30 nM
Compound 4: the middle estimate sits 6.0-fold (0.78 log units) below what was measured; measured number outside the range, above it.
By their numbers in this assay, from the lowest: compound 3; then compounds 1, 2 and 4 (each within the scatter of the next, the first and the last beyond it).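

On this amine nitrogen, a six-membered aromatic ring alone does not secure the low number, since phenylcarbamoyl carries one just as benzyl does (a 30-fold higher number from compound 3 to compound 4 (1.48 log units; beyond the scatter)). Phenylcarbamoyl sits level with the bare amine (a 1.5-fold higher number from compound 2 to compound 4 (0.18 log units; within the scatter)) and above the tert-butoxycarbonyl compound, with anilino in place of tert-butoxy on the carbonyl carbon (a 3.0-fold higher number from compound 1 to compound 4 (0.48 log units; beyond the scatter)), so among these four compounds only benzyl stands apart. Nothing available explains this difference. As far as these compounds go, whether the carbonyl or the extra nitrogen matters more stays open, and benzoyl or 2-phenylethyl on this nitrogen would help separate the two.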